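Ethyl oxime ether on the methyl-substituted piperazine: cytotoxicity outlook

The source may hold more compounds than are shown below. What is called first, only, known or untested is meant among the compounds shown, and "the series" means these compounds.

Measured compounds:
- compound 1 `CCON=C1CCC(CN2CCN(c3nc(=O)c4cc(C(F)(F)F)cc([N+](=O)[O-])c4s3)CC2)CC1`: > 64 ug/mL
- compound 2 `CON=C1CCC(CN2CCN(c3nc(=O)c4cc(C(F)(F)F)cc([N+](=O)[O-])c4s3)C[C@@H]2C)CC1`: > 64 ug/mL

Both measured compounds were tested in an ADME assay on Vero cells (Chlorocebus sabaeus) for cytotoxicity; a higher number here means that more compound is tolerated, a lower number that less compound is tolerated. Compound 1 gives > 64 ug/mL, which is a limit of the assay rather than a number. Compound 2 likewise gives > 64 ug/mL, again a limit of the assay. Compound 2 therefore stands where every value shown stands, at the limit of > 64 ug/mL in this assay, at which 2 of the 2 values shown sit, and nothing separates it from compound 1 in this assay.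

Compound 3 `CCON=C1CCC(CN2CCN(c3nc(=O)c4cc(C(F)(F)F)cc([N+](=O)[O-])c4s3)C[C@@H]2C)CC1` has not yet been measured. It differs from compound 2 by methyl in place of hydrogen on a saturated chain carbon bound to an oxygen on an unsaturated carbon, which is the same difference that separates compound 1 from compound 2 apart from the methyl on the piperazine ring. With compound 1 at > 64 ug/mL, the step is expected to be a number no higher from compound 2 to compound 3 (the limit leaves the size open), that is, none beyond the scatter. Compound 3 is estimated at 64 ug/mL, between 40 ug/mL and 100 ug/mL.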

Compound 3, half-maximal cytotoxic concentration: > 64 ug/mL
Compound 3 gave a limit, no number (the forecaster's own chance of this, stated with the estimate: 85%); the middle value sits exactly at the limit.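

In this assay compound 1, compound 2 and compound 3 all give a limit rather than a number, so no step between them can be read: the limit of > 64 ug/mL in this assay, at which 3 of the 3 values shown sit.

The compounds shown leave open how much of each compound the cells actually tolerate, and whether methyl in place of hydrogen changes that at all.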